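This account rests on a few compounds, and the source may have more. Where it says the series, first, only, none or still open, it means among the compounds named here.

Compound 1 `CSc1ccc(S(=O)(=O)NC(=O)Nc2ccc(Cl)cc2)s1` and compound 2 `CCOc1ccc(S(=O)(=O)NC(=O)Nc2ccc(Cl)cc2)s1` share one core and differ at a single aromatic carbon. In a functional assay on the whole organism (6C3HED cells, Mus musculus) for inhibition, at a dose of 300 mg/kg by the oral route (on this read-out higher numbers stand for more inhibition at the one dose given (going by the name of the read-out) and lower numbers for less inhibition), compound 1 gives 62%, while compound 2 gives 96%, the higher of the two numbers, with the step of a number 34 percentage points higher from compound 1 to compound 2 (beyond the scatter). Compound 3 `CCCc1ccc(S(=O)(=O)NC(=O)Nc2ccc(Cl)cc2)s1` carries the change (propyl in place of ethoxy on an aromatic carbon). Going by the values given here, no measured step covers this exchange directly; the one step at hand only shows how much a single change at this position can shift this assay. With the acceptor gone and compound 2 already near the top, the number for compound 3 is expected to fall, by about a number 21 percentage points lower from compound 2 to compound 3 (beyond the scatter). Compound 3 is therefore estimated at 75%, within 45% to 98%.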

Compound 3, a percentage reported as inhibition, in the whole organism at one dose (the size of the read-out at that dose, not a potency): 39%
The estimate for compound 3 lay 36 percentage points above the measured number; the measured number lies below the stated range.
By their numbers in this assay, from the lowest: compound 3; then compound 1; then compound 2.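

At this place, next to the ring sulfur, the count of heavy atoms alone does not set the number: ethoxy and propyl each hold 3 heavy atoms, yet this assay shows a number 57 percentage points lower from compound 2 to compound 3 (beyond the scatter) for that exchange. Methylsulfanyl also gives way to propyl with a loss, a number 23 percentage points lower from compound 1 to compound 3 (beyond the scatter), so compound 3 stands lowest of the three. Nothing available gives a cause for these steps. Going by these compounds, whether a methoxy or an amine at this carbon would hold the number up, and whether a butyl chain would lower it further, remains open.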